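Tetrabromobenzotriazole series: hydroxyalkyl chain variation and antiproliferative activity

The compounds below may be only part of what the source reports. "The series", "measured", "known", "first", "only" and "open" are said of these compounds alone.

Measured so far:
compound 1, `OC(CCn1nc2c(Br)c(Br)c(Br)c(Br)c2n1)c1cccc(Br)c1`, 1%
compound 2, `C[C@@H](O)CCn1nc2c(Br)c(Br)c(Br)c(Br)c2n1`, 18%

In a functional assay on MCF7 cells (Homo sapiens) for antiproliferative activity, read by MTT assay, with a stated time of 24 h, tested at 100 uM (a higher number here means a weaker effect of the compound at the concentration tested, a lower number a stronger effect), compound 2 gives 18%, the highest of the two numbers, and its nearest neighbour compound 1 gives 1%, a gap beyond the usual scatter. Compound 3, `OCC(O)Cn1nc2c(Br)c(Br)c(Br)c(Br)c2n1`, has not yet been measured. It differs from compound 2 by 1,2-dihydroxyethyl in place of 2-hydroxypropyl on a saturated chain carbon bound to an aromatic nitrogen. Among the measured compounds shown here, no measured pair tells how such a change acts on this series, so a step of at most modest size is expected, with no direction established beyond the scatter. Compound 3 is estimated at 22%, within 5% to 45%, a step of a number 4 percentage points higher from compound 2 to compound 3 (within the scatter).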

Compound 3, a percentage reported as activity, at one concentration (the size of the read-out at that concentration, not a potency): 53%
Compound 3: the middle estimate sits 31 percentage points below what was measured; measured number outside the range, above it.
By their numbers in this assay, from the lowest: compound 1; then compound 2; then compound 3.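

In this assay the change to 1,2-dihydroxyethyl in place of 2-hydroxypropyl on a saturated chain carbon bound to an aromatic nitrogen gives a number 35 percentage points higher from compound 2 to compound 3 (beyond the scatter) and so a weaker effect at the concentration tested. This place in the series therefore responds strongly to a swap between two chains of 4 heavy atoms each. Nothing available explains the step.

Still open, going by these compounds, is whether the added hydroxyl or the lost methyl carries the step, as the change makes both at once. On these data alone, how an amine, a carboxylic acid or a longer chain would read in this place also remains unknown.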